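The source may report more compounds than this note shows. Statements on the series, on what has been measured and on what is new or still open speak of the compounds shown alone.

Two sulfonamides of the shared core have been measured. Compound 1 `CC(C)(C)c1ccc(CNCCNS(=O)(=O)c2cc(C(F)(F)F)cc(C(F)(F)F)c2)cc1` gives 15000 nM in a functional assay on MIA PaCa-2 cells (Homo sapiens) for inhibition, read by MTT assay, with a stated time of 72 h; a lower number here means a stronger inhibitor of growth, a higher number a weaker inhibitor of growth. Compound 2 `COc1cccc(CNCCCNS(=O)(=O)c2cc(C(F)(F)F)cc(C(F)(F)F)c2)c1` gives 3400 nM in this assay, the lowest of the two numbers, with compound 1 standing a good way higher and beyond the scatter. Going by the values given here, compound 1 and compound 2 differ in more than one place, so their two values show no single structural step.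

Compound 3 `O=S(=O)(NCCCNCc1ccccc1)c1cc(C(F)(F)F)cc(C(F)(F)F)c1` is the next compound to be tested. It differs from compound 2 in one place: hydrogen in place of methoxy on an aromatic carbon. Among the compounds with values here, no measured pair isolates this change, so no step size is known for it. Compound 3 is expected to keep most of the potency of compound 2, with a modest move a 1.5-fold higher number from compound 2 to compound 3 (0.17 log units; within the scatter) towards a weaker inhibitor of growth in this assay, since removing a substituent from the benzylamino side is not expected to be decisive. The estimate for compound 3 is 5000 nM, with a range from 2000 nM to 15000 nM.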

Compound 3, concentration for 50% growth inhibition: 11000 nM
For compound 3 the middle estimate is 2.2-fold (0.34 log units) below the measured one; the range from low to high includes it.
By their numbers in this assay, from the lowest: compound 2; then compounds 3 and 1 (each within the scatter of the next).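

Taking the methoxy off the 3-methoxybenzyl group is the first single change that can be read in this assay, and it gives a 3.2-fold higher number from compound 2 to compound 3 (0.51 log units; beyond the scatter), a step towards a weaker inhibitor of growth. The methoxy on this aromatic carbon, meta to a large group, therefore matters in this pair, with compound 2 the stronger inhibitor of growth. Nothing measured here accounts for the size of this step.

On these data alone, whether this step belongs to the methoxy itself or would also appear with another substituent at this place, such as a hydroxy, a fluorine or a methyl group, stays open. Also open, as far as these compounds go, is whether the methoxy would have the same effect on a longer chain or on a benzyl group carrying it at another place on the ring.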